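Compound 4 Against Three Solubility Limits

The compounds below may be only part of what the source reports. "The series", "measured", "known", "first", "only" and "open" are said of these compounds alone.

Three compounds share one core. Compound 1 `O=C(O)c1ccc(C(=O)/C(=C\c2ccc(F)c([N+](=O)[O-])c2)SCc2ccc(Cl)cc2)cc1`, compound 2 `O=C(O)c1ccc(C(=O)/C(=C\c2ccc(Br)c([N+](=O)[O-])c2)SCc2ccc(Br)cc2)cc1` and compound 3 `O=C(O)c1ccc(C(=O)/C(=C\c2ccc(F)c([N+](=O)[O-])c2)SCc2ccc(C(F)(F)F)cc2)cc1` have been measured in a physicochemical assay for solubility; on this read-out higher numbers stand for higher solubility and lower numbers for lower solubility. In this assay compound 1 gives < 1000 ug/mL, which is a limit of the assay rather than a number. Compound 2 gives < 1000 ug/mL, again a limit. Compound 3 gives < 1000 ug/mL, also a limit. Going by the values given here, compound 2 therefore stands at the limit of < 1000 ug/mL in this assay, at which 3 of the 3 values shown sit, where every value so far sits. The step that the two limits leave unreadable from compound 1 to compound 3 cannot be read for the same reason. Compound 4 `O=C(O)c1ccc(C(=O)/C(=C\c2ccc([N+](=O)[O-])c(F)c2)SCc2ccc(Br)cc2)cc1` differs from compound 2 by 3-fluoro-4-nitrophenyl in place of 4-bromo-3-nitrophenyl on a double-bonded chain carbon bound to a double-bonded chain carbon. Among the compounds with values here, no measured step bears on this change, and the three limits give no direction. Compound 4 is expected to give 300 ug/mL, within 30 ug/mL to 1000 ug/mL. The expected step that the limit leaves unreadable from compound 2 to compound 4 is thus none beyond the scatter, with a further limit the likeliest outcome.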

Compound 4, solubility: < 1000 ug/mL
Compound 4: no number, only a limit; the forecaster's own chance of this, stated with the estimate: 80%; the middle value is on the limit's open side.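

No step can be read from compound 2 to compound 4 in this assay, and all values remain at one limit: the limit of < 1000 ug/mL in this assay, at which 4 of the 4 values shown sit.

The compounds shown leave open where any of them actually stands, and so what 3-fluoro-4-nitrophenyl in place of 4-bromo-3-nitrophenyl does to this read-out.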